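Oxime ether series: cyanomethyl in place of pyridinylmethyl

A few compounds are considered here, and "the series" means these few. Any claim that something is new, unique, unknown or untested is made for them only; others in the source may bear on it.

Three members of this series have numbers in a functional assay (blood) for inhibition, with Homo sapiens as the target; on this read-out lower numbers stand for stronger inhibition and higher numbers for weaker inhibition. Compound 1 `CO[C@]1(c2cc(F)cc(S(=O)(=O)c3ccc(/C(C)=N/O)cc3)c2)CCO[C@@H](C)C1` gives 20 nM in this assay. Compound 2 `C/C(=N\OCc1ccncc1)c1ccc(Sc2cc(F)cc(C3CCOCC3)c2)cc1` gives 300 nM, and compound 3 `C/C(=N\OCC(O)CO)c1ccc(S(=O)(=O)c2cccc(C3CCOCC3)c2)cc1` gives 160 nM. Compound 2 thus carries the highest of the three numbers; its nearest neighbour is compound 3, whose number lies within the scatter of repeated measurements, so no order can be read between these two. Its furthest neighbour is compound 1, whose number is beyond the scatter and clearly lower, so compound 2 inhibits more weakly than compound 1 on this read-out.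

The next compound, compound 4 `C/C(=N\OCC#N)c1ccc(Sc2cc(F)cc(C3CCOCC3)c2)cc1`, is built from compound 2 by one change: cyano in place of pyridin-4-yl on a saturated chain carbon bound to an oxygen. For the measured compounds named here, no pair of measured compounds in the set differs in one place only, so no measured step stands behind this change. The three numbers at hand span a range in which the oxime ether chain differs between compounds 2 and 3 together with other changes, and their numbers sit within the scatter of each other.

On this basis, compound 4 is expected to show a step of a 1.2-fold lower number from compound 2 to compound 4 (0.08 log units; within the scatter) that stays within the scatter. Compound 4 is therefore estimated at 250 nM in this assay, with a range from 80 nM to 800 nM.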

Compound 4, half-maximal inhibitory concentration: 20 nM
Beside the measured number, compound 4's estimate is 13-fold (1.10 log units) above it, outside the stated range (below it).
By their numbers in this assay, from the lowest: compounds 1 and 4 (each within the scatter of the next); then compounds 3 and 2 (each within the scatter of the next).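

Notes on the oxime ether end: the saturated chain carbon bound to an oxygen is now shown to be a sensitive position, since in this assay cyano in place of pyridin-4-yl gives a 15-fold lower number from compound 2 to compound 4 (1.18 log units; beyond the scatter). For the compounds shown here, this is the first step read in one place, and it is large and beyond the scatter, whereas the earlier compounds differed in several places at once and could not assign any change to this chain. The counted difference is that a six-membered aromatic ring of 6 heavy atoms leaves and a group of 2 heavy atoms with a triple bond enters, with 0 hydrogen-bond donors and 1 hydrogen-bond acceptor on each side, and no measurement at hand bears on why the step is this large.

This single step cannot separate the loss of the pyridin-4-yl ring from the arrival of the nitrile, a question that a simple methyl, a longer cyanoethyl chain or a carboxylic acid at this place would bear on. On these data alone, whether the same change carries over to the core of compound 3 also remains open.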